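This account rests on a few compounds, and the source may have more. Where it says the series, first, only, none or still open, it means among the compounds named here.

Compound 1, `COc1ccc(OCC2=NCCO2)cc1`: 70%
Compound 2, `Brc1ccccc1OCC1=NCCO1`: 90%

Of the compounds shown here, two sharing the same core have been tested so far. In a toxicity assay on the whole organism with Rattus norvegicus as the target, at a dose of 200 mg/kg by the oral route (on this read-out higher numbers stand for a stronger effect at the one dose given and lower numbers for a weaker effect), compound 2 gives 90%, the highest of the two numbers. Its nearest neighbour is compound 1, which gives 70% in this assay, a gap that lies beyond the usual scatter of repeated measurements. Going by the values given here, compound 1 and compound 2 differ in more than one place, so no single change can be read from their two values; they show only that compound 2 is the stronger of the pair.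

Compound 3, `Clc1ccccc1OCC1=NCCO1`, has not yet been measured. It differs from compound 2 in one place only: chloro in place of bromo on an aromatic carbon. The two groups exchanged are each a single heavy atom, neither adds nor removes a hydrogen-bond donor or acceptor, and no charge changes. No comparable exchange has been measured among the compounds here, so the size of the step rests on judgement alone. Such a small swap is expected to move the number only a little, if at all beyond the scatter, and in the downward direction if anywhere. Compound 3 is therefore expected to give about 82%, within a range from 62% to 96%. The step of a number 8 percentage points lower from compound 2 to compound 3 (within the scatter) expected from this estimate is small, with compound 2 at 90% serving as the anchor.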

Compound 3, a percentage reported as activity, at one dose (the size of the read-out at that dose, not a potency): 40%
Estimate against measurement, compound 3: 42 percentage points above; the measured number lies below the stated range.
By their numbers in this assay, from the lowest: compound 3; then compound 1; then compound 2.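

In this assay the swap of chloro in place of bromo, on an aromatic carbon ortho to a group of 7 heavy atoms, gives a number 50 percentage points lower from compound 2 to compound 3 (beyond the scatter) and so shows that the number is sensitive to which of these two groups sits at this position. The earlier pair, compound 1 and compound 2, differed in more than one place and could not show this, whereas here the whole step belongs to one change, between two groups that both carry 0 hydrogen-bond donors, 0 hydrogen-bond acceptors and no net charge, so those counts do not tell them apart. Nothing available here accounts for a step of this size.

From the compounds shown here alone, with only bromo and chloro compared at this position, it remains open how fluoro, iodo, a methyl group or an amine would read there, and so whether the numbers follow any order across such groups. It is also open whether the same exchange would give a step of similar size at another place on the ring, since this one pair is the only exchange shown.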